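Adding a methyl to the sulfonamide-bearing ring

A few compounds are considered here, and "the series" means these few. Any claim that something is new, unique, unknown or untested is made for them only; others in the source may bear on it.

Measured compounds:
compound 1 `COc1cc2c(c(Oc3cccc(NS(=O)(=O)c4ccc(Cl)cc4)c3)n1)C(=O)N(C1CC1)C2=O` gives 19 nM
compound 2 `Cc1cc2c(c(Sc3cccc(NS(=O)(=O)c4ccc(Cl)cc4)c3)n1)C(=O)N(C(C)C)C2=O` gives 19 nM

Both compounds were tested in a functional assay on HEK293 cells for agonist activity at Glucose-dependent insulinotropic receptor (Homo sapiens), read by cAMP accumulation, with a stated time of 30 min; on this read-out lower numbers stand for an effect already at smaller amounts and higher numbers for an effect only at larger amounts of compound. Compound 1 gives 19 nM and compound 2 gives 19 nM, so compound 2 stands level with compound 1 at the digits shown, and the two fall within the usual scatter of each other. Neither can be called the more potent.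

Compound 3 `Cc1cc2c(c(Sc3ccc(C)c(NS(=O)(=O)c4ccc(Cl)cc4)c3)n1)C(=O)N(C(C)C)C2=O` has not yet been measured. It differs from compound 2 in one place: methyl in place of hydrogen on an aromatic carbon. The new methyl sits on an aromatic carbon of a six-membered aromatic ring of carbon only, ortho to a ((4-chlorophenyl)sulfonyl)amino group and para to a large group. Among the compounds with values here, no measured pair shows what such a change does here, so the data give no direction. Because compound 2 gives 19 nM, the expectation is a step of a 1.2-fold higher number from compound 2 to compound 3 (0.06 log units; within the scatter) that stays within the scatter, with no clear direction. Compound 3 is therefore estimated at 22 nM, with a range from 7 nM to 70 nM in this assay.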

Compound 3, half-maximal effective concentration: 224 nM
For compound 3 the middle estimate is 10-fold (1.01 log units) below the measured one; measured number outside the range, above it.
By their numbers in this assay, from the lowest: compounds 1 and 2 (each within the scatter of the next); then compound 3.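

In this assay, a single methyl in place of hydrogen on the sulfonamide-bearing ring, ortho to a ((4-chlorophenyl)sulfonyl)amino group and para to a large group, moves the number by a 12-fold higher number from compound 2 to compound 3 (1.07 log units; beyond the scatter) and so costs a large amount of potency. Compound 1 and compound 2 differ in more than one place, so they could not show what any single change does, whereas this pair shows that this ring position is not indifferent to substitution: a group of just one carbon, with no ring, hydrogen-bond donors, hydrogen-bond acceptors or net charge, is enough to produce a step well beyond the scatter. Nothing measured here gives a reason for the size of this step.

The compounds shown leave open whether the loss belongs to methyl alone or would also follow from another group at this position, such as fluorine, a hydroxyl or an amine. They also leave open whether a methyl on another carbon of the same ring, or on the same carbon of the ring in compound 1, would cost as much.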